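Ortho substituent swap on the benzylic ring of compound 2

The source may hold more compounds than are shown below. What is called first, only, known or untested is meant among the compounds shown, and "the series" means these compounds.

Measured compounds:
Compound 1, `Cc1ccc(-c2nc(N)c3cc(CCc4ccccc4)sc3n2)o1`: 2780 nM
Compound 2, `COc1ccccc1Cc1cc2c(N)nc(-c3ccc(C)o3)nc2s1`: 122 nM

Within the data shown here, compound 2 holds the lower of the two numbers measured in a functional assay on CHO-K1 cells for antagonist activity at adenosine receptor A1 (Homo sapiens), read by a beta-galactosidase reporter and cAMP accumulation, with stated times of 15 min and 6 h; a lower number here means a stronger inhibitor, a higher number a weaker inhibitor; the only other measured compound, compound 1, sits at 2780 nM. Among the measured compounds shown here, the one measured step, a 23-fold lower number from compound 1 to compound 2 (1.36 log units; beyond the scatter), is the whole of what is known about the benzylic ring on this core.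

Compound 3 is `Cc1ccc(-c2nc(N)c3cc(Cc4ccccc4F)sc3n2)o1`. It differs from compound 2 by fluoro in place of methoxy on an aromatic carbon. The step from compound 1 to compound 2 bears on this change only indirectly: it shows that putting a methoxy group onto the benzylic ring moved the number a long way down, but it says nothing about a fluoro group in that same place. For the measured compounds named here, no measured pair separates the contribution of the methoxy oxygen from that of simply having any group there.

The expectation for compound 3 is therefore a number lying between compound 1 and compound 2, with a step of a 4.9-fold higher number from compound 2 to compound 3 (0.69 log units; beyond the scatter) upward, estimated at 600 nM with a range from 150 nM to 2500 nM.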

Compound 3, inhibition constant: < 16 nM
Compound 3 ended at the assay's limit (the forecaster's own chance of this, stated with the estimate: 5%); middle value at least 37-fold (1.57 log units) from the limit.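

In this assay, compound 3 is read only as a limit of the assay, not as a number: the limit of < 16 nM in this assay, at which 1 of the 3 values shown sits. Even so, the change of methoxy to fluoro, on the same aromatic carbon ortho to a large group, gives an at least 7.6-fold lower number from compound 2 to compound 3 (0.88 log units; beyond the scatter), so the low number of compound 2 does not depend on the methoxy group, and the hydrogen-bond acceptor counted for it is not required at this place. Set against the chain-linked phenyl of compound 1, the 2-fluorophenyl group gives an at least 170-fold lower number from compound 1 to compound 3 (2.23 log units; beyond the scatter), which shows that this position can carry a single fluoro and still reach the lowest reading among the compounds shown.

The compounds shown leave open how far compound 3 really lies under its limit, and how much of the steps from compound 1 belongs to the ring substituent and how much to the difference in the chain. Going by these compounds, it also remains open whether chloro, methyl or hydroxyl in the same place, or an unsubstituted phenyl on the same one-carbon link, would give a number as low.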